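A few compounds are considered here, and "the series" means these few. Any claim that something is new, unique, unknown or untested is made for them only; others in the source may bear on it.

Compound 1 `O=C(NCc1ccc(C(=O)N2CCCCc3ccccc32)c(F)c1)Nc1c(F)cccc1F` gives 180 nM in a functional assay on HEK293 cells for agonist activity at Vasopressin V2 receptor (Homo sapiens), read by a luciferase reporter and cAMP accumulation; a lower number here means that less compound is needed, a higher number that more compound is needed for the effect. Compound 2 `Cc1cc(C(=O)N2CCCCc3ccccc32)cc(C)c1CNC(=O)Nc1c(F)cccc1F` gives 82 nM in this assay. Compound 3 `COC(=O)CNC(=O)NCc1ccc(C(=O)N2CCCCc3ccccc32)cc1C` gives 37 nM in this assay.

Of the three, compound 3 has the lowest number; compound 2 lies nearest to it, beyond the usual scatter, and compound 1 lies furthest. Compound 4 `Cc1cc(C(=O)N2CCCCc3ccccc32)ccc1CNC(=O)NCC(=O)N1CCCC1` differs from compound 3 in one place: pyrrolidin-1-yl in place of methoxy on a carbonyl carbon. Among the compounds with values here, no measured pair shows this change, so its effect is unknown; nothing among the three compounds points either way, and a step within or only slightly beyond the scatter is expected. Compound 4 is therefore estimated at 50 nM in this assay, between 15 nM and 170 nM, which amounts to an expected step of a 1.4-fold higher number from compound 3 to compound 4 (0.13 log units; within the scatter).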

Compound 4, half-maximal effective concentration: 100 nM
The estimate for compound 4 lay 2.0-fold (0.30 log units) below the measured number; the measured number falls inside the stated range.
By their numbers in this assay, from the lowest: compound 3; then compounds 2, 4 and 1 (each within the scatter of the next, the first and the last beyond it).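

Putting pyrrolidin-1-yl in place of methoxy on this carbonyl carbon gives a 2.7-fold higher number from compound 3 to compound 4 (0.43 log units; beyond the scatter) in this assay. Within the data shown here, this is the first one-place comparison, and it shows that the number responds, modestly, to the group on this carbonyl carbon. No measurement offered here explains the step.

From the compounds shown here alone, it remains open whether the ring or simply the nitrogen in place of oxygen on the carbonyl carbon goes with the higher number. Neither a dimethylamino group nor the carboxylic acid at this place is among the compounds shown.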